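This account rests on a few compounds, and the source may have more. Where it says the series, first, only, none or still open, it means among the compounds named here.

Measured so far in a physicochemical assay for solubility, in phosphate buffer, at pH 7.4; on this read-out higher numbers stand for higher solubility and lower numbers for lower solubility:
- compound 1 `Fc1ccc(Nc2cc(-c3ccnc(Nc4ccc(F)cc4)c3)ccn2)cc1`: < 100 nM (a limit of the assay)
- compound 2 `COC1CCC(C(=O)Nc2cc(-c3ccnc(Nc4ccccc4)c3)ccn2)CC1`: 8000 nM
- compound 3 `COCCC(=O)Nc1cc(-c2ccnc(Nc3ccccc3)c2)ccn1`: 20000 nM

Compound 3, at 20000 nM, holds the higher of the two actual numbers in this assay, and its nearest neighbour is compound 2 at 8000 nM. Compound 1 stands at the limit of < 100 nM in this assay, at which 1 of the 3 values shown sits. For the measured compounds named here, that entry is a limit, and no measured step connects compound 1 to the others.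

The next compound is compound 4 `Cc1cnc(C(=O)Nc2cc(-c3ccnc(Nc4ccccc4)c3)ccn2)cn1`, with 5-methylpyrazin-2-yl in place of 2-methoxyethyl on a carbonyl carbon.

Going by the values given here, one measured step bears on this change, at the same carbonyl carbon: a 2.5-fold higher number from compound 2 to compound 3 (0.40 log units; beyond the scatter). It is modest but beyond the scatter, and it shows the same 2-methoxyethyl group giving the higher number. Among the compounds with values here, compound 2 is the only measured comparison with a ring in this place, at 8000 nM. Within the data shown here, no aromatic ring has yet been measured here, so the single step is a weak guide and the range must stay wide.

A modest fall in this assay is expected, somewhat larger than the measured step. The estimated step is a 3.3-fold lower number from compound 3 to compound 4 (0.52 log units; beyond the scatter). For compound 4 the estimated value is 6000 nM, with an expected range of 1500 nM to 20000 nM.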

Compound 4, solubility: 40000 nM
Compound 4: the middle estimate sits 6.7-fold (0.82 log units) below what was measured, outside the stated range (above it).
By their numbers in this assay, from the lowest: compound 2; then compounds 3 and 4 (each within the scatter of the next). At a limit, below all of these: compound 1.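

In this assay, putting 5-methylpyrazin-2-yl in place of 2-methoxyethyl on the carbonyl carbon gives a 2.0-fold higher number from compound 3 to compound 4 (0.30 log units; within the scatter), so an aromatic ring at this place cannot be told apart from the open chain. Set against 4-methoxycyclohexyl, the same aromatic group gives a 5.0-fold higher number from compound 2 to compound 4 (0.70 log units; beyond the scatter), a modest step that lies beyond the scatter, as does a 2.5-fold higher number from compound 2 to compound 3 (0.40 log units; beyond the scatter), which leaves compound 2 apart from the other two amides. Having a ring at this place therefore does not by itself set the number: compound 2 and compound 4 both carry one and differ beyond the scatter, whereas compound 3 carries none and stays within the scatter of compound 4.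

Still open, on these data alone, is where a plain phenyl ring, a chain ending in an amine or a chain ending in a carboxylic acid on this carbonyl carbon would fall, and whether the methyl on the 5-methylpyrazin-2-yl group matters to the number. Nothing at hand gives a reason for the gap between compound 2 and the other two amides.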